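Swapping the aryl ether group on a triazine core

A few compounds are considered here, and "the series" means these few. Any claim that something is new, unique, unknown or untested is made for them only; others in the source may bear on it.

Measured compounds:
- compound 1, `NC1=NC2(CCOCC2)N(OCCCOc2cc(Cl)c(Cl)cc2Cl)C(N)=N1`: "not determined" (no result reported)
- compound 2, `CC(C)(C)c1ccc(OCCCON2C(N)=NC(N)=NC23CCSCC3)cc1`: 1 nM
- compound 3, `COc1ccc(OCCCON2C(N)=NC(N)=NC23CCSCC3)cc1`: 350 nM

In a functional assay on MDA-MB-231 cells (Homo sapiens) for antiproliferative activity, read by MTT assay, with a stated time of 72 h (on this read-out higher numbers stand for weaker inhibition and lower numbers for stronger inhibition), compound 1 has no result; its place among the numbers is therefore unknown. Compound 2 and compound 3 share a core that differs from the core of compound 1 and carry different groups on the aryl ether. In this assay compound 2 gives 1 nM while compound 3 gives 350 nM, and the step of a 350-fold higher number from compound 2 to compound 3 (2.54 log units; beyond the scatter) shows how strongly this assay answers to a change on that ring.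

Compound 4, `Cc1cc(C)cc(OCCCON2C(N)=NC(N)=NC23CCOCC3)c1`, keeps the core of compound 1 and changes only the aryl ether: 3,5-dimethylphenyl in place of 2,4,5-trichlorophenyl on an oxygen on a saturated carbon. Among the measured compounds shown here, the only measured step that touches the same ring is the one from compound 2 to compound 3, on a different core, so it bears only loosely here, and with no number for compound 1 no step size can be given. On the strength of compound 2 at 1 nM and compound 3 at 350 nM, compound 4 is expected to land between them, estimated at 20 nM with a range of 2 nM to 300 nM.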

Compound 4, half-maximal inhibitory concentration: 3570 nM
Compound 4: the middle estimate sits 180-fold (2.25 log units) below what was measured; measured number outside the range, above it.
By their numbers in this assay, from the lowest: compound 2; then compound 3; then compound 4.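

In this assay no new step can be read for compound 4: compound 1, which differs from it in one place, has no single number. Nothing measured here accounts for the result of compound 4. Open, on these data alone, is how 3,5-dimethylphenyl and 2,4,5-trichlorophenyl compare on this shared core.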